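The compounds below may be only part of what the source reports. "The series", "measured", "known", "first", "only" and "open" are said of these compounds alone.

Compound 1 `CCN1CCc2c(sc(NC(=O)[C@@H]3CCCN3)c2C(N)=O)C1` is known in a functional assay (strain AB) with Danio rerio as the target, read by microscopy, with a stated time of 1 h (on this read-out lower numbers stand for an effect already at smaller amounts and higher numbers for an effect only at larger amounts of compound), only as a limit: compound 1 gives > 25000 nM. Compound 2 `CCN1CCc2c(sc(N)c2C(N)=O)C1` likewise gives > 25000 nM, again a limit. Among the measured compounds shown here, the single measured step, a step that the two limits leave unreadable from compound 1 to compound 2, is therefore unreadable, as the limit of > 25000 nM in this assay, at which 2 of the 2 values shown sit, shows. Compound 3 `CCN1CCc2c(sc(NC(=O)Nc3ccc(Br)cc3)c2C(N)=O)C1` differs from compound 1 by (4-bromophenyl)amino in place of pyrrolidin-2-yl on a carbonyl carbon. No readable step bears on this change, so neither direction nor size can be drawn from the series. The change is expected to amount to a step that the limit leaves unreadable from compound 1 to compound 3, most probably ending again at a limit. Compound 3 is accordingly estimated at 30000 nM, within 5000 nM to 150000 nM.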

Compound 3, half-maximal effective concentration: 3130 nM
Compound 3: the middle estimate sits 9.6-fold (0.98 log units) above what was measured; measured number outside the range, below it.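

In this assay, among the compounds shown here, the carbonyl carbon is the first place where a change can be read: (4-bromophenyl)amino in place of pyrrolidin-2-yl brings an at least 7.9-fold lower number from compound 1 to compound 3 (0.90 log units; beyond the scatter). The size of this step is a minimum, as compound 1 is known only as a limit. Compound 3 carries a number, while the other values remain limits: the limit of > 25000 nM in this assay, at which 2 of the 3 values shown sit.

As far as these compounds go, whether the bromine or the aromatic ring carries the step stays open. Also open, from the compounds shown here alone, is what a plain phenylamino or a cyclohexylamino group would give on this carbonyl carbon.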